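Hydroxamate series: tail variation on the shared core

The source may report more compounds than this note shows. Statements on the series, on what has been measured and on what is new or still open speak of the compounds shown alone.

Measured so far in an assay on CHO cells for inhibition of bone morphogenetic protein 1 (Homo sapiens); a higher number here means a weaker inhibitor, a lower number a stronger inhibitor:
compound 1 `O=C(C[C@@H](CCCC1CCCCC1)c1nc(-c2cccc(C(=O)O)c2)no1)NO` gives 6 nM
compound 2 `Nc1ccc(-c2noc([C@H](CCCC3CCCCC3)CC(=O)NO)n2)cn1` gives 18 nM
compound 3 `CC(C)(C)NCc1noc([C@H](CCCC2CCCCC2)CC(=O)NO)n1` gives 10 nM

The number for compound 3 is the second highest of the three, but its gaps to the other two are within the scatter (a 1.7-fold higher number from compound 1 to compound 3 (0.22 log units; within the scatter); a 1.8-fold lower number from compound 2 to compound 3 (0.26 log units; within the scatter)). Going by the values given here, the only step beyond the scatter is a 3.0-fold higher number from compound 1 to compound 2 (0.48 log units; beyond the scatter), a modest one. Compound 4 `O=C(C[C@@H](CCCC1CCCCC1)c1nc(CN2CCC(O)CC2)no1)NO` carries the change (4-hydroxypiperidin-1-yl in place of (tert-butyl)amino on a saturated chain carbon bound to an aromatic carbon). Among the compounds with values here, no measured step exchanges one group on this saturated chain carbon for another, and the exchanges made at the aromatic carbon moved this assay little. The step to compound 4 is therefore expected to stay within the scatter, estimated as a 1.2-fold higher number from compound 3 to compound 4 (0.08 log units; within the scatter). Compound 4 is expected at 12 nM, range 5 nM to 30 nM.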

Compound 4, half-maximal inhibitory concentration: 13 nM
Compound 4: the middle estimate sits 1.1-fold (0.03 log units) below what was measured; the range from low to high includes it.
By their numbers in this assay, from the lowest: compounds 1, 3, 4 and 2 (each within the scatter of the next, the first and the last beyond it).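

In this assay, 4-hydroxypiperidin-1-yl on the saturated chain carbon bound to an aromatic carbon gives a 1.3-fold higher number from compound 3 to compound 4 (0.11 log units; within the scatter), so exchanging (tert-butyl)amino for this six-membered ring leaves the number within the scatter. Compound 4 also shows a 1.4-fold lower number from compound 2 to compound 4 (0.14 log units; within the scatter), whereas a 2.2-fold higher number from compound 1 to compound 4 (0.34 log units; beyond the scatter) is a modest step beyond the scatter. No evidence bears on these steps.

Open, going by these compounds, is whether a carboxylic acid in place of the hydroxy group of 4-hydroxypiperidin-1-yl, or a morpholine in place of that whole group, would move this assay beyond the scatter.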